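Swapping a thiocarbonyl group for a fluorinated amide

The compounds below may be only part of what the source reports. "The series", "measured", "known", "first", "only" and "open" are said of these compounds alone.

Three compounds share one core and differ only in the group carried on the ring nitrogen. Compound 1 `Cc1nc(S(C)(=O)=O)ccc1Oc1ncnc(OC2CCN(C(=O)OC(C)(C)C#N)CC2)c1F` gives 97% in a functional assay on isolated protein for inhibition of Glucose-dependent insulinotropic receptor (Rattus norvegicus), read by HTRF and cAMP accumulation; a higher number here means a larger maximal response, a lower number a smaller maximal response. Compound 2 `Cc1nc(S(C)(=O)=O)ccc1Oc1ncnc(OC2CCN(C(=O)SC(C)C)CC2)c1F` gives 81% in this assay, and compound 3 `Cc1nc(S(C)(=O)=O)ccc1Oc1ncnc(OC2CCN(C(=S)OC3(C)CC3)CC2)c1F` gives 49%. Compound 3 therefore stands lowest of the three: the step of a number 48 percentage points lower from compound 1 to compound 3 (beyond the scatter) and the step of a number 32 percentage points lower from compound 2 to compound 3 (beyond the scatter) are both large and beyond the scatter, while the step of a number 16 percentage points lower from compound 1 to compound 2 (beyond the scatter) is modest.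

Compound 4 `Cc1nc(S(C)(=O)=O)ccc1Oc1ncnc(OC2CCN(C(=O)C(C)(C)F)CC2)c1F` is not yet measured. It differs from compound 3 by a group of 6 heavy atoms (4 carbon, 1 oxygen, 1 fluorine; no ring) in place of a group of 7 heavy atoms (5 carbon, 1 oxygen, 1 sulfur; one three-membered non-aromatic ring of carbon only), on an amine nitrogen in a ring. All three measured steps alter this same position, so all bear on the question: the two steps into compound 3 were large losses, the step between compound 1 and compound 2 a modest one. Because compound 3 sits at 49%, the lowest of the set, a replacement that takes away the thiocarbonyl group is expected to recover part of that loss, and an upward step a number 29 percentage points higher from compound 3 to compound 4 (beyond the scatter) is expected. The value for compound 4 is estimated at 78%, within a range from 58% to 95%.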

Compound 4, largest response reached (reported as efficacy), in percent of the reference or control that the assay uses: 74%
Beside the measured number, compound 4's estimate is 4 percentage points above it; low and high end bracket the measured number.
By their numbers in this assay, from the lowest: compound 3; then compounds 4 and 2 (each within the scatter of the next); then compound 1.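

The step of a number 25 percentage points higher from compound 3 to compound 4 (beyond the scatter) in this assay shows that the low number of compound 3 does not apply to every group at this position: (1-fluoro-1-methylethyl)carbonyl, which has no sulfur, gives a larger maximal response. The step of a number 7 percentage points lower from compound 2 to compound 4 (within the scatter) means that this swap cannot be told apart from the scatter, whereas the step of a number 23 percentage points lower from compound 1 to compound 4 (beyond the scatter) leaves the 1-cyano-1-methylethoxy group of compound 1 clearly ahead. No measurement here explains any of these differences.

From the compounds shown here alone, the change from compound 3 to compound 4 replaces the thiocarbonyl, its oxygen link and the three-membered ring all at once, so the contribution of each part remains open. A 1-methylcyclopropoxycarbonyl group, the carbonyl counterpart of the group in compound 3, could help separate them, and an isobutyryl group could show what the fluorine contributes.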